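Chloro to Nitro on the Aryl Ring of Compound 3

This account rests on a few compounds, and the source may have more. Where it says the series, first, only, none or still open, it means among the compounds named here.

Three compounds have been measured in a functional assay on Huh-7 cells (Homo sapiens) for inhibition, read by sulforhodamine B assay, with a stated time of 72 h; on this read-out higher numbers stand for weaker inhibition and lower numbers for stronger inhibition:
compound 1 `Cc1ccc(C2=Nn3c(nnc3C(C)c3ccc(-c4ccccc4)c(F)c3)SC2)cc1` gives 7200 nM;
compound 2 `CC(C)Cc1ccc(C(C)c2nnc3n2N=C(c2ccc(F)cc2)CS3)cc1` gives 7800 nM;
compound 3 `CC(C)Cc1ccc(C(C)c2nnc3n2N=C(c2ccc(Cl)cc2)CS3)cc1` gives 5700 nM.

Compound 3 has the lowest of these three numbers, but its gaps to compound 1 and to compound 2 both lie within the scatter, so no order among the three can be read from them. Compound 4 `CC(C)Cc1ccc(C(C)c2nnc3n2N=C(c2ccc([N+](=O)[O-])cc2)CS3)cc1` differs from compound 3 by nitro in place of chloro on an aromatic carbon. Going by the values given here, the only measured step at this same place is a 1.4-fold lower number from compound 2 to compound 3 (0.14 log units; within the scatter), which stayed within the scatter. Among the compounds with values here, no measured compound carries a nitro group, so nothing is known about that group here. For compound 4 a step of no more than the scatter is therefore expected, no change at the digits printed from compound 3 to compound 4 (within the scatter). Compound 4 is estimated at 5700 nM, within a range from 2000 nM to 16000 nM.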

Compound 4, half-maximal inhibitory concentration: "not active" (no number reported)
Compound 4: no number reported; there is nothing to compare the estimate with.
By their numbers in this assay, from the lowest: compounds 3, 1 and 2 (each within the scatter of the next).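

Going by these compounds alone, compound 4 is reported only as "not active", without a number, so no step from compound 3 to compound 4 can be read. On these data alone, whether 4-nitrophenyl in place of 4-chlorophenyl changes inhibition, and how far, stays open, and no other evidence bears on this result.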